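A few compounds are considered here, and "the series" means these few. Any claim that something is new, unique, unknown or untested is made for them only; others in the source may bear on it.

Measured so far:
compound 1, `CN(C)c1ccc(/C=C/c2cc(=O)c(O)c[nH]2)cc1`, 3410 nM
compound 2, `O=c1cc(/C=C/c2ccc([N+](=O)[O-])cc2)[nH]cc1O`, 4790 nM
compound 3, `CN(C)c1ccc(/C=C/c2cc(=O)c(O)cn2C)cc1`, 2520 nM

All three values come from a functional assay, with a stated time of 10 min; a lower number here means a stronger inhibitor, a higher number a weaker inhibitor. The three compounds share a core built around a vinyl link to a benzene ring, and they differ in two places. Compound 1 and compound 2 differ only on the benzene ring: nitro in place of dimethylamino on an aromatic carbon. That change gave a 1.4-fold higher number from compound 1 to compound 2 (0.15 log units; within the scatter), so the two values are not distinguishable by this assay. Compound 1 and compound 3 differ only on the core: methyl in place of hydrogen on an aromatic nitrogen. That change gave a 1.4-fold lower number from compound 1 to compound 3 (0.13 log units; within the scatter), again a step that cannot be told apart from repeat scatter.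

Compound 4, `Cn1cc(O)c(=O)cc1/C=C/c1ccc([N+](=O)[O-])cc1`, has not yet been measured in this assay. It carries the core of compound 3 and the benzene substituent of compound 2, so it stands to compound 3 as compound 2 stands to compound 1: nitro in place of dimethylamino on an aromatic carbon. The surroundings of the change are the same in both pairs, so it is the same change, seen a second time.

Going by the values given here, the only guide to its effect is the pair of compound 1 and compound 2, where the step of a 1.4-fold higher number from compound 1 to compound 2 (0.15 log units; within the scatter) stayed within scatter. Because the step of a 1.4-fold lower number from compound 1 to compound 3 (0.13 log units; within the scatter) also stayed small, the core change gives no hint that the new core will respond differently. The expected step from compound 3 to compound 4 is therefore a 1.4-fold higher number from compound 3 to compound 4 (0.14 log units; within the scatter), a step of about the size seen before. On that basis compound 4 is estimated at 3500 nM, most likely between 1800 nM and 7000 nM.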

Compound 4, half-maximal inhibitory concentration: 19200 nM
Compound 4: the middle estimate sits 5.5-fold (0.74 log units) below what was measured; measured number above the stated range.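

In this assay, nitro in place of dimethylamino gave a 7.6-fold higher number from compound 3 to compound 4 (0.88 log units; beyond the scatter), so this change did not carry over unchanged from the core of compound 1 to the core of compound 3: the same change on two cores in this assay, a 1.4-fold higher number (0.15 log units; within the scatter) from compound 1 to compound 2 and a 7.6-fold higher number (0.88 log units; beyond the scatter) from compound 3 to compound 4, 5.4-fold (0.73 log units) apart, beyond the scatter of two such steps. Methyl in place of hydrogen on an aromatic nitrogen gave a 4.0-fold higher number from compound 2 to compound 4 (0.60 log units; beyond the scatter), and this change did not carry over unchanged either, since its effect depended on which benzene substituent was present: the same change on two cores in this assay, a 1.4-fold lower number (0.13 log units; within the scatter) from compound 1 to compound 3 and a 4.0-fold higher number (0.60 log units; beyond the scatter) from compound 2 to compound 4, 5.4-fold (0.73 log units) apart, beyond the scatter of two such steps. These four compounds show that the two changes do not act independently here, so a step read on one core is a poor guide to the same step on the other, but they do not show why this happens or whether it holds for any other pair of groups.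

The compounds shown leave open how other groups in place of dimethylamino or nitro, such as a primary amine, a methoxy group or a carboxylic acid, would behave on each of the two cores. They also leave open whether a longer chain on the aromatic nitrogen, such as ethyl or propyl, would follow methyl.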